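Trimming a Methyl from the Linker of Compound 3

A few compounds are considered here, and "the series" means these few. Any claim that something is new, unique, unknown or untested is made for them only; others in the source may bear on it.

Of the compounds shown here, three built on one shared core have been measured in an assay on cells with melanin-concentrating hormone receptor 1 (Homo sapiens) as the target, read by radioligand binding; a higher number here means a weaker inhibitor, a lower number a stronger inhibitor. Compound 1 `CC(CNCC1CCCC1)Oc1cccc2ccc(N)nc12` gives 100 nM in this assay, compound 2 `CC(CN1CCCC1)Oc1cccc2ccc(N)nc12` gives 70 nM, and compound 3 `CC(CNCc1ccoc1)Oc1cccc2ccc(N)nc12` gives 10 nM. The step of a 1.4-fold lower number from compound 1 to compound 2 (0.15 log units; within the scatter) lies within the scatter, so those two cannot be ranked against each other. The steps of a 10-fold lower number from compound 1 to compound 3 (1.00 log units; beyond the scatter) and a 7.0-fold lower number from compound 2 to compound 3 (0.85 log units; beyond the scatter) both lie beyond the scatter, which makes compound 3 the strongest inhibitor of the three.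

Compound 4 `Nc1ccc2cccc(OCCNCc3ccoc3)c2n1` has not yet been measured. It differs from compound 3 by hydrogen in place of methyl on a saturated chain carbon bound to an oxygen on an aromatic ring and a saturated chain carbon. Going by the values given here, none of the measured steps touch this part of the molecule: all three alter the amine end of the chain and leave the methyl-bearing carbon as it is. Among the compounds with values here, no measured step therefore bears directly on the change, and the data give no guide to its direction. In that situation the expectation is a step of a 1.5-fold higher number from compound 3 to compound 4 (0.18 log units; within the scatter), which would not exceed the scatter. Compound 4 is thus estimated to give about 15 nM in this assay, within a range from 5 nM to 45 nM.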

Compound 4, half-maximal inhibitory concentration: 660 nM
Estimate against measurement, compound 4: 44-fold (1.64 log units) below, outside the stated range (above it).
By their numbers in this assay, from the lowest: compound 3; then compounds 2 and 1 (each within the scatter of the next); then compound 4.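

Taking away one methyl, a single carbon with no ring, no hydrogen-bond donor or acceptor and no net charge, gives a 66-fold higher number from compound 3 to compound 4 (1.82 log units; beyond the scatter) in this assay and so shows that this saturated chain carbon is a sensitive position. This single-carbon change has a larger effect than either step beyond the scatter seen earlier at the amine end of the chain, so the methyl-bearing carbon matters at least as much as that end for this series. Nothing measured here explains why the loss of the methyl costs so much.

Going by these compounds, whether an ethyl group on this carbon would give a lower or a higher number than methyl remains open. Also open, on these data alone, is whether the methyl counts for as much with pyrrolidin-1-yl at the amine end, as only compound 3 and compound 4 form a pair that differs at this carbon.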